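The compounds below may be only part of what the source reports. "The series", "measured", "known", "first", "only" and "open" are said of these compounds alone.

Of the compounds shown here, three have been tested in a functional assay on MCF7 cells (Homo sapiens) for antiproliferative activity, with a stated time of 96 h (on this read-out lower numbers stand for stronger inhibition and higher numbers for weaker inhibition), so far. Going by the values given here, compound 1 (`Cc1cc(=O)oc2cc(OCC(=O)c3ccccc3C(F)(F)F)ccc12`) gives 43200 nM in this test, the only actual number available and a weak result. Compound 2 (`COc1cccc(C(=O)COc2ccc3c(C(F)(F)F)cc(=O)oc3c2)c1`) is recorded as "not active" (no number reported) with no figure attached. Compound 3 (`O=C(COc1ccc2c(C(F)(F)F)cc(=O)oc2c1)c1ccccc1C(F)(F)F`) is also recorded as "not active" (no number reported) with no figure attached, so it has no exact place on the numerical scale. One compound remains unmeasured, compound 4 (`O=C(COc1ccc2c(C(F)(F)F)cc(=O)oc2c1)c1ccccc1`). The structural change is hydrogen in place of trifluoromethyl on an aromatic carbon and it amounts to hydrogen in place of trifluoromethyl on an aromatic carbon. Among the compounds with values here, no measured pair shows what this swap does in this assay, so no large gain in potency is expected. The likely outcome is that compound 4 stays weak, landing near compound 1 at 43200 nM or again giving no number. In this assay the estimated value for compound 4 is 50000 nM with an expected range from 20000 nM to 100000 nM if a number is reported at all.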

Compound 4, half-maximal inhibitory concentration: "not active" (no number reported)
Compound 4 has no reported number here; the estimate stays without a comparison.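

Going by these compounds alone, compound 3 and compound 4 are both recorded as "not active" in this assay with no number, so no step between them can be read. The compounds shown leave open how replacing trifluoromethyl with hydrogen changes potency here. No measurement offers an explanation for this result.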